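The source may report more compounds than this note shows. Statements on the series, on what has been measured and on what is new or still open speak of the compounds shown alone.

Measured so far in an ADME assay on Vero cells (Chlorocebus sabaeus) for cytotoxicity, with a stated time of 5 days; a lower number here means a stronger inhibitor, a higher number a weaker inhibitor:
compound 1 `O=C(/C=C/c1ccc(N2CCCCC2)cc1)c1ccc(Br)s1` — 69500 nM
compound 2 `Cc1ccsc1C1=NNC(c2ccc(N3CCCCC3)cc2)C1` — 11400 nM
compound 3 `Cc1ccc(C2=NNC(c3ccc(N4CCCCC4)cc3)C2)s1` — 52000 nM

Compound 3 stands second highest of the three numbers in this assay. Its nearest neighbour is compound 1, whose number is higher but within the scatter, so no order between the two can be read. Compound 2 lies beyond the scatter below compound 3.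

Compound 4 `Clc1cc(C2=NNC(c3ccc(N4CCCCC4)cc3)C2)c(Cl)s1` is not yet measured. It differs from compound 3 in one place: 2,5-dichlorothiophen-3-yl in place of 5-methylthiophen-2-yl on a carbon with a double bond to nitrogen. Within the data shown here, the only measured step that touches the same group is a 4.6-fold higher number from compound 2 to compound 3 (0.66 log units; beyond the scatter), where the methyl merely moved within the ring and the number shifted by a modest amount. Among the measured compounds shown here, no measured compound carries a chlorine, so nothing speaks directly to the present change. A step of similar order in either direction is plausible, with no strong reason to favour one side.

The number for compound 4 in this assay is estimated at 35000 nM, with a range from 10000 nM to 110000 nM. That estimate means a step of a 1.5-fold lower number from compound 3 to compound 4 (0.17 log units; within the scatter) is expected.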

Compound 4, half-maximal inhibitory concentration: 53900 nM
The estimate for compound 4 lay 1.5-fold (0.19 log units) below the measured number, and the stated range covers the measured number.
By their numbers in this assay, from the lowest: compound 2; then compounds 3, 4 and 1 (each within the scatter of the next).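

In this assay, 2,5-dichlorothiophen-3-yl in place of 5-methylthiophen-2-yl on the carbon with a double bond to nitrogen gives no readable shift (a 1.0-fold higher number from compound 3 to compound 4 (0.02 log units; within the scatter)), so this position accepts a larger substituted thiophene, with two chlorines and a different ring connection, without leaving the scatter. Set against 3-methylthiophen-2-yl, the same group gives a clear step (a 4.7-fold higher number from compound 2 to compound 4 (0.67 log units; beyond the scatter)), so among compounds 2, 3 and 4, only compound 2 stands apart at this position. Nothing at hand explains these numbers.

Still open, on these data alone, is whether the lower number of compound 2 depends on its methyl, which an unsubstituted thiophene at this position would test. Also open, as far as these compounds go, is whether a phenyl ring, or a thiophene bearing an amine or a carboxylic acid, would move the number beyond the scatter.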